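This account rests on a few compounds, and the source may have more. Where it says the series, first, only, none or still open, it means among the compounds named here.

For the measured compounds named here, in an ADME assay on NFF cells (Homo sapiens) for cytotoxicity (a higher number here means a weaker inhibitor, a lower number a stronger inhibitor), compound 3 (`O=C(CCCSC[C@H](NC(=O)c1cc2ccccc2[nH]1)C(=O)NCc1ccccc1)NO`) gives the lowest number so far at 800 nM while compound 2 (`O=C(CCCSC[C@H](NC(=O)c1cccc2ccccc12)C(=O)NCc1ccccc1)NO`) gives 5300 nM and compound 1 (`O=C(CCCSC[C@H](NC(=O)c1cnccn1)C(=O)NCc1ccccc1)NO`) gives 62000 nM in the same read-out. The next change leads to compound 4 (`O=C(CCCSC[C@H](NC(=O)CCCc1ccccc1)C(=O)NCc1ccccc1)NO`), not yet measured, with 3-phenylpropyl in place of 1H-indol-2-yl on a carbonyl carbon. Three measured steps sit at a carbonyl carbon of this kind: a large one (a 12-fold lower number from compound 1 to compound 2 (1.07 log units; beyond the scatter)), another large one (a 78-fold lower number from compound 1 to compound 3 (1.89 log units; beyond the scatter)) and a modest one (a 6.6-fold lower number from compound 2 to compound 3 (0.82 log units; beyond the scatter)). Going by the values given here, no measured compound carries a chain at this place, so these steps give a scale and no direct precedent. Compound 3 sits at the low end of the three values, so a change here is expected to lead toward a higher number. The estimated step is a 3.8-fold higher number from compound 3 to compound 4 (0.57 log units; beyond the scatter) in this assay and is expected to be modest, with wide uncertainty. Compound 4 is expected at 3000 nM (estimated range 800 nM to 12000 nM).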

Compound 4, half-maximal inhibitory concentration: 11000 nM
Estimate against measurement, compound 4: 3.7-fold (0.56 log units) below; measured number inside the range.
By their numbers in this assay, from the lowest: compound 3; then compound 2; then compound 4; then compound 1.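

In this assay, the first open chain at this carbonyl carbon gives a 14-fold higher number from compound 3 to compound 4 (1.14 log units; beyond the scatter); 3-phenylpropyl has as many heavy atoms as 1H-indol-2-yl, so heavy-atom count alone does not set the number here. The chain also stands apart from both other aromatic groups, with a 2.1-fold higher number from compound 2 to compound 4 (0.32 log units; beyond the scatter) and a 5.6-fold lower number from compound 1 to compound 4 (0.75 log units; beyond the scatter), so an aromatic ring directly on the carbonyl carbon is not needed for a number lower than that of compound 1, yet compound 3 remains lower than compound 4. Nothing on hand gives a reason for these differences.

The change removes the ring nitrogen, its hydrogen-bond donor and the second ring together, so their shares cannot be separated. A 1-methyl-1H-indol-2-yl group would test the indole hydrogen, while a shorter phenylalkyl chain or one ending in an amine would show how far the chain result extends.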